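This account rests on a few compounds, and the source may have more. Where it says the series, first, only, none or still open, it means among the compounds named here.

Compound 1 `Nc1nc(-c2ccccc2)cn1/N=C/c1cc2ccccc2nc1Cl`: 16400 nM
Compound 2 `Cc1ccc(-c2cn(/N=C/c3cc4ccccc4nc3Cl)c(N)n2)cc1`: > 50000 nM
Compound 3 `Nc1nc(-c2cccc3ccccc23)cn1/N=C/c1cc2ccccc2nc1Cl`: 9480 nM

In a functional assay on DLD-1 cells (Homo sapiens) for cytotoxicity, read by MTT assay, with a stated time of 48 h (on this read-out higher numbers stand for weaker inhibition and lower numbers for stronger inhibition), compound 1 gives 16400 nM. Compound 2 differs from it by one change, (methyl in place of hydrogen on an aromatic carbon), and its value is a limit of the assay rather than a number, (the limit of > 50000 nM in this assay, at which 1 of the 3 values shown sits). The step from one to the other is an at least 3.0-fold higher number from compound 1 to compound 2 (0.48 log units; beyond the scatter). Compound 3 carries a different core; how it differs from compound 1 is not broken down here. In this assay compound 3 gives 9480 nM, a number within the scatter of that of compound 1.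

Compound 4 `Cc1ccc2nc(Cl)c(/C=N/n3cc(-c4cccc5ccccc45)nc3N)cc2c1` is not yet measured. It differs from compound 3 by methyl in place of hydrogen on an aromatic carbon. This is the same kind of change as that from compound 1 to compound 2, but not the same: there the methyl sat para to a large group, here it sits on a ring that is part of a fused system of two rings, meta to a fused ring and para to a fused ring. Resting on the weakening seen in an at least 3.0-fold higher number from compound 1 to compound 2 (0.48 log units; beyond the scatter), a step of a 2.1-fold higher number from compound 3 to compound 4 (0.32 log units; beyond the scatter) is expected, with compound 4 estimated at 20000 nM in this assay, between 7000 nM and 50000 nM.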

Compound 4, half-maximal inhibitory concentration: 8300 nM
Estimate against measurement, compound 4: 2.4-fold (0.38 log units) above; measured number inside the range.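

In this assay, methyl in place of hydrogen on an aromatic carbon gave a 1.1-fold lower number from compound 3 to compound 4 (0.06 log units; within the scatter), and on this core the change therefore made no readable difference. Set beside the earlier step, the same change did not carry over from one core to the other: the same change on two cores in this assay, an at least 3.0-fold higher number (0.48 log units; beyond the scatter) from compound 1 to compound 2 and a 1.1-fold lower number (0.06 log units; within the scatter) from compound 3 to compound 4, at least 3.4-fold (0.54 log units) apart, beyond the scatter of two such steps Compound 2 stands at > 50000 nM, a limit of the assay and not a number, and these two pairs do not show whether the core or the different place of the methyl lies behind the gap.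

The compounds shown leave open how the methyl would read if it stood on the same ring as in compound 4 but on the core of compound 1, which would separate place from core. They also leave open whether a longer chain such as ethyl, or a methoxy group, an amine or a carboxylic acid at that place would stay level with compound 3.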